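Trimming the phenol side chain of compound 3

A few compounds are considered here, and "the series" means these few. Any claim that something is new, unique, unknown or untested is made for them only; others in the source may bear on it.

Compound 3 `COc1ccc(C(c2ccc(OCCO)cc2)c2cccc3ccccc23)c(OC)c1OC` gives in a functional assay on HCT-116 cells (Homo sapiens) for inhibition, read by sulforhodamine B assay, with a stated time of 48 h (on this read-out higher numbers stand for weaker inhibition and lower numbers for stronger inhibition), a result reported only as a limit of the assay, > 20000 nM. The same holds for compound 2 `COc1ccc(C(OCc2ccccc2)c2cccc3ccccc23)c(OC)c1OC`, whose value in this assay is likewise a limit, > 20000 nM. the limit of > 20000 nM in this assay, at which 2 of the 3 values shown sit, marks where both stand. Compound 1 `COc1ccc(C(c2ccc(OC(C)CN(C)C)cc2)c2cccc3ccccc23)c(OC)c1OC`, carrying 1-((dimethylamino)methyl)ethyl on the oxygen of the aromatic ring, is the only one of the three with a number in this assay, 8410 nM. The step from compound 1 to compound 3 reads an at least 2.3-fold higher number from compound 1 to compound 3 (0.37 log units; beyond the scatter), and the step from compound 2 to compound 3 is a step that the two limits leave unreadable from compound 2 to compound 3.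

Compound 4 `COc1ccc(C(c2ccccc2O)c2cccc3ccccc23)c(OC)c1OC` differs from compound 3 in one place: 2-hydroxyphenyl in place of 4-(2-hydroxyethoxy)phenyl on a saturated chain carbon bound to two aromatic carbons. Both measured steps alter the group on the saturated chain carbon or its attached oxygen, and both end with compound 3 at the limit, so neither gives a readable direction for this further change. Compound 4 is therefore expected to sit near where compound 3 sits, with the step from compound 3 to compound 4 estimated as a step that the limit leaves unreadable from compound 3 to compound 4. The estimate for compound 4 in this assay is 25000 nM, within a range from 8000 nM to 80000 nM, and it is expected most likely to be reported again only as a limit.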

Compound 4, half-maximal inhibitory concentration: > 20000 nM
Compound 4: a limit, no number; the forecaster's own chance of this, stated with the estimate: 70%; the middle value does not contradict the limit.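

For compound 4, this assay gives > 20000 nM, a limit of the assay and not a number, so its steps from compound 2 and compound 3 cannot be read. The compounds shown leave open how 2-hydroxyphenyl, 4-(2-hydroxyethoxy)phenyl and benzyloxy differ from one another in this assay, with most values resting at one mark: the limit of > 20000 nM in this assay, at which 3 of the 4 values shown sit.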